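A few compounds are considered here, and "the series" means these few. Any claim that something is new, unique, unknown or untested is made for them only; others in the source may bear on it.

Compound 1: `Cc1cc(C)c(NC(=O)N(Cc2ccc(-c3ccn(C)n3)cc2)C2CCCCCC2)c(C)c1`
Compound 2: `Cc1cc(C)c(NC(=O)N(Cc2cccc(-c3ccn(C)n3)c2)C2CCCCCC2)c(C)c1`
Compound 3: `Cc1cc(C)c(NC(=O)N(Cc2ccc(-c3ccnn3C)cc2)C2CCCCCC2)c(C)c1`

In a functional assay on a cell-free system (plasma) with sterol O-acyltransferase, Soat (Rattus norvegicus) as the target (a higher number here means that more compound is needed for the effect, a lower number that less compound is needed), compound 1 gives < 1 mg/kg, a limit of the assay rather than a number. Compound 2 gives < 1 mg/kg in this assay, again a limit. Compound 3 gives < 1 mg/kg in this assay, also a limit. Compound 3 arises from compound 1 by 1-methyl-1H-pyrazol-5-yl in place of 1-methyl-1H-pyrazol-3-yl on an aromatic carbon and the step is a step that the two limits leave unreadable from compound 1 to compound 3, since both values sit at the limit of < 1 mg/kg in this assay, at which 3 of the 3 values shown sit. Compound 2 differs from compound 1 in the shared core, and that difference is not broken down here.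

Compound 4, `Cc1cc(C)c(NC(=O)N(Cc2cccc(-c3ccnn3C)c2)C2CCCCCC2)c(C)c1`, is still to be measured. It arises from compound 2 by 1-methyl-1H-pyrazol-5-yl in place of 1-methyl-1H-pyrazol-3-yl on an aromatic carbon. This is the same kind of change as from compound 1 to compound 3, but the place differs: in compound 3 the new group sits para to a large group, in compound 4 meta to a large group. The step from compound 2 to compound 4 in this assay is expected to be a step that the limit leaves unreadable from compound 2 to compound 4, small, because compound 1 and compound 3 both sit at the limit of < 1 mg/kg in this assay, at which 3 of the 3 values shown sit. Compound 4 is therefore expected to give about 0.5 mg/kg in this assay, likely reported again as a limit, between 0.1 mg/kg and 1.5 mg/kg.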

Compound 4, dose for half-maximal effect: > 1 mg/kg
Compound 4: a limit, no number (the forecaster's own chance of this, stated with the estimate: 80%); at least 2.0-fold (0.30 log units) between middle value and limit.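

In this assay, putting 1-methyl-1H-pyrazol-5-yl in place of 1-methyl-1H-pyrazol-3-yl on the core of compound 2, where the group sits meta to a large group, gives a number no lower from compound 2 to compound 4 (the limit leaves the size open). From the compounds shown here alone, compound 4 gives > 1 mg/kg, which is a limit of the assay and not a number, so the change on this core does not lower the dose needed, but the size of the step remains unknown. The same change on the core of compound 1 gives a step that cannot be read, so the data do not show whether the change acts alike or differently on the two cores: the limit of < 1 mg/kg in this assay, at which 3 of the 4 values shown sit.

Going by these compounds, all four values shown are limits, so the actual dose for each compound and the true size of each step stay open. Also open, on these data alone, is how a different group at the same place, such as an amine or a carboxylic acid, would fare in this assay.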